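A difluorophenyl swap on compound 2

The compounds below may be only part of what the source reports. "The series", "measured", "known", "first", "only" and "open" are said of these compounds alone.

Compound 1 `Cc1nc(C(NC(=O)C(=O)Nc2ccc(Cl)cc2)C2CCCN2)sc1CO`: 45000 nM
Compound 2 `Cc1ccc(NC(=O)C(=O)NC(c2nc(C)c(CCO)s2)C2CCCCN2)c(F)c1`: > 78800 nM

Both figures come from an ADME assay on MT2 cells (Homo sapiens) for cytotoxicity, read by XTT assay, with a stated time of 4 days (on this read-out lower numbers stand for higher toxicity in this test and higher numbers for lower toxicity in this test), and only one of them is a true number. Compound 2 gives > 78800 nM as a limit of the assay, not a number.

Compound 3 `Cc1nc(C(NC(=O)C(=O)Nc2ccc(F)c(F)c2)C2CCCCN2)sc1CCO` is not yet measured. Its difference from compound 2 is 3,4-difluorophenyl in place of 2-fluoro-4-methylphenyl on an amide-type nitrogen and amounts to 3,4-difluorophenyl in place of 2-fluoro-4-methylphenyl on an amide-type nitrogen. Among the compounds with values here, no measured pair shows what a single change does here, so no direction can be favoured. The expected result is an at least 1.1-fold lower number from compound 2 to compound 3 (0.05 log units; that floor lies within the scatter) and this estimate is no larger than the usual scatter. Compound 1 gives 45000 nM as a number, so a number rather than a limit remains possible for compound 3. For compound 3 the estimate is 70000 nM with an expected range of 30000 nM to 150000 nM as the likely span.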

Compound 3, half-maximal cytotoxic concentration: > 78200 nM
Compound 3: only a limit was reported; the forecaster's own chance of this, stated with the estimate: 60%; middle value at least 1.1-fold (0.04 log units) away from the limit.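

In this assay compound 2 gives > 78800 nM, a limit and not a number. Compound 3 gives > 78200 nM, also a limit, and no step can be read from compound 2 to compound 3. What the compounds shown leave open is what 3,4-difluorophenyl in place of 2-fluoro-4-methylphenyl does to the cytotoxic concentration.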